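This account rests on a few compounds, and the source may have more. Where it says the series, first, only, none or still open, it means among the compounds named here.

Measured compounds:
Compound 1 `N=C(S)CCCCCCN1N=C(c2ccccc2)CCC1=O` gives 72.3 mg/kg in a functional assay on the whole organism (stomach) for inhibition, with Rattus norvegicus as the target; a lower number here means that less compound is needed, a higher number that more compound is needed for the effect.
Compound 2 `CC(Cn1nc(-c2ccccc2)ccc1=O)C(=N)S` gives 35 mg/kg in this assay.
Compound 3 `C/N=C(\S)C(C)Cn1ncccc1=O` gives 68.5 mg/kg in this assay.

Among these three, compound 2 shows the lowest number in this assay. Its gap to compound 3 lies within the usual scatter of the measurement, so no order between compound 2 and compound 3 can be read from the values. Its gap to compound 1 lies just beyond the scatter, so compound 2 needs less material than compound 1 for the same effect.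

Compound 4 `N=C(S)CCn1nc(-c2ccccc2)ccc1=O` has not yet been measured. It differs from compound 2 in one place: hydrogen in place of methyl on a saturated chain carbon bound to a carbon with a double bond to nitrogen and a saturated chain carbon. The shared core and the side group on the ring are untouched; only the methyl on the saturated chain is lost.

Among the measured compounds shown here, no pair of measured compounds differing in just one place is available, so the effect of this change cannot be read from a known step. Given that compound 3 carries a methyl at the corresponding chain position and shows 68.5 mg/kg, while compound 1 carries none and shows 72.3 mg/kg, close to each other, the loss of the methyl is expected to bring no step beyond the scatter. Compound 4 is therefore estimated at 45 mg/kg in this assay, with a range from 18 mg/kg to 110 mg/kg, a step of a 1.3-fold higher number from compound 2 to compound 4 (0.11 log units; within the scatter) that is expected to stay within the scatter.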

Compound 4, dose for half-maximal effect: 53.5 mg/kg
Compound 4: middle estimate off by 1.2-fold (0.08 log units), on the low side, and the stated range covers the measured number.
By their numbers in this assay, from the lowest: compounds 2, 4, 3 and 1 (each within the scatter of the next, the first and the last beyond it).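

Hydrogen in place of methyl on a saturated chain carbon bound to a carbon with a double bond to nitrogen and a saturated chain carbon gives a 1.5-fold higher number from compound 2 to compound 4 (0.18 log units; within the scatter) in this assay and is the first direct reading of this change, with the shared core and the phenyl-bearing side of the molecule held constant. Earlier, this position could only be approached through compounds that differed in several places at once, whereas this single pair shows that losing the methyl leaves the number within the scatter, so no order between the two compounds can be read and the methyl is not required for a measurable effect on this core. No measurement is available that would explain the size of this step.

Going by these compounds, what remains open is whether a larger group at this carbon, such as an ethyl or a phenyl, or a different one, such as a hydroxyl or an amine, would move the number beyond the scatter. The compounds shown also leave open whether the same change would read alike on a longer chain or on a core without the phenyl.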